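Methyl to isopropyl among compounds read only as limits

The source may report more compounds than this note shows. Statements on the series, on what has been measured and on what is new or still open speak of the compounds shown alone.

Of the compounds shown here, three have been read in an ADME assay on MT4 cells (Homo sapiens) for cytotoxicity, read by MTT assay (on this read-out lower numbers stand for higher toxicity in this test and higher numbers for lower toxicity in this test), so far: compound 1 (`O=C(CSc1nc(Cc2c(F)cccc2Cl)cc(=O)[nH]1)c1ccccc1`), compound 2 (`Cc1c(Cc2c(F)cccc2Cl)nc(SCC(=O)c2ccccc2)[nH]c1=O`) and compound 3 (`COc1ccc(C(=O)CSc2nc(Cc3c(F)cccc3Cl)c(C)c(=O)[nH]2)cc1`). Compound 1 gives > 13000 nM as a limit of the assay. Compound 2 stands at > 12000 nM as a limit as well, so it has no number of its own. Compound 3 gives > 12000 nM as a limit too.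

Compound 4 (`CC(C)c1c(Cc2c(F)cccc2Cl)nc(SCC(=O)c2ccccc2)[nH]c1=O`) carries isopropyl in place of methyl on an aromatic carbon of compound 2, the change being isopropyl in place of methyl on an aromatic carbon in full. Among the measured compounds shown here, two measured steps bear on it. Methyl in place of hydrogen on an aromatic carbon gave a step that the two limits leave unreadable from compound 1 to compound 2 in this assay and methoxy in place of hydrogen on an aromatic carbon gave a step that the two limits leave unreadable from compound 2 to compound 3 on the same read-out. Neither offers a size to carry over, so no step beyond the scatter is expected, and another limit is the likely report. The expected step is a number no higher from compound 2 to compound 4 (the limit leaves the size open) as an estimate. For compound 4 the estimated value is 12000 nM with an expected range from 5000 nM to 30000 nM in all.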

Compound 4, half-maximal cytotoxic concentration: > 12000 nM
Compound 4 gave a limit, no number (the forecaster's own chance of this, stated with the estimate: 75%); the middle value lies on the limit itself.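

In this assay compound 4 gives > 12000 nM, a limit and not a number. Its steps from compound 1 and compound 2 therefore cannot be read. The compounds shown leave open what concentration would be half-maximally cytotoxic for any of them, and whether hydrogen, methyl and isopropyl on that aromatic carbon differ at all.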